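Cyclopentylcarbonyl in place of acetyl on the piperidine amide

The source may report more compounds than this note shows. Statements on the series, on what has been measured and on what is new or still open speak of the compounds shown alone.

In an assay on L1.2 cells for binding affinity to C-C chemokine receptor type 8 (Homo sapiens) (on this read-out lower numbers stand for stronger inhibition and higher numbers for weaker inhibition), compound 1 `CCOC(=O)N1CCC(NS(=O)(=O)c2ccc(NCc3ccccc3)c3ccccc23)CC1` gives 45.6 nM, and compound 2 `CC(=O)N1CCC(NS(=O)(=O)c2ccc(NC(=O)c3ccccc3C)c3ccccc23)CC1` gives 6.7 nM, the lowest of the two numbers shown and beyond the scatter of compound 1. Compound 3 `Cc1ccccc1C(=O)Nc1ccc(S(=O)(=O)NC2CCN(C(=O)C3CCCC3)CC2)c2ccccc12` is not yet measured. It differs from compound 2 by cyclopentyl in place of methyl on a carbonyl carbon, so the larger ring only enlarges the acyl group at the ring nitrogen. Within the data shown here, no step between measured compounds isolates this change, and a small shift in either direction, or none beyond the scatter, is expected for compound 3 a 1.0-fold higher number from compound 2 to compound 3 (0.02 log units; within the scatter). The estimate for compound 3 in this assay is 7 nM, with a range from 2.5 nM to 20 nM.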

Compound 3, inhibition constant: 9.1 nM
The estimate for compound 3 lay 1.3-fold (0.11 log units) below the measured number; measured number inside the range.
By their numbers in this assay, from the lowest: compounds 2 and 3 (each within the scatter of the next); then compound 1.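

In this assay, cyclopentyl in place of methyl on a carbonyl carbon gives a 1.4-fold higher number from compound 2 to compound 3 (0.13 log units; within the scatter), so compound 2 and compound 3 cannot be told apart on this read-out. At this position, acetyl and cyclopentylcarbonyl therefore read alike, and the five-membered carbon ring brings no loss beyond the scatter. Nothing available explains this result.

Still open, as far as these compounds go, is how an amine or a carboxylic acid on this carbonyl carbon would read. From the compounds shown here alone, a longer straight chain or an aromatic ring at the same place is equally open.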